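Replacing the fluorophenyl arm with trifluoromethoxy

A few compounds are considered here, and "the series" means these few. Any claim that something is new, unique, unknown or untested is made for them only; others in the source may bear on it.

Of the compounds shown here, three sharing one core have been measured. Compound 1 `Cc1n[nH]c(C(=O)O)c1Cc1cccc(-c2cccc(F)c2)c1` gives 50% in an assay on isolated protein for inhibition of 2-Hydroxyacid oxidase 2 (Homo sapiens), tested at 10 uM; a higher number here means a stronger effect of the compound at the concentration tested, a lower number a weaker effect. Within the data shown here, compound 3 `Cc1n[nH]c(C(=O)O)c1Cc1ccccc1Oc1ccccc1` gives 49%, a number that sits within the usual scatter of the one for compound 1, so no order can be read between them. Compound 2 `Cc1n[nH]c(C(=O)O)c1Cc1ccc(C(F)(F)F)cc1` gives 12%, a number well beyond the scatter below compound 1. Compound 1 thus holds the highest of the three numbers, with compound 3 close beside it and compound 2 far below.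

Compound 4 `Cc1n[nH]c(C(=O)O)c1Cc1cccc(OC(F)(F)F)c1` has not yet been measured. It differs from compound 1 in one place: trifluoromethoxy in place of 3-fluorophenyl on an aromatic carbon. Among the measured compounds shown here, no measured pair isolates this change, so its size can only be guessed from the values shown.

Compound 2, which carries a small fluorinated group in place of a second ring, gives 12%, and on that basis a drop beyond the scatter is expected from compound 1 to compound 4, of about a number 28 percentage points lower from compound 1 to compound 4 (beyond the scatter). For compound 4 the expected value is 22%, within a range from 5% to 45%.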

Compound 4, a percentage reported as inhibition, at one concentration (the size of the read-out at that concentration, not a potency): 26%
Estimate against measurement, compound 4: 4 percentage points below; the measured number falls inside the stated range.
By their numbers in this assay, from the lowest: compound 2; then compound 4; then compounds 3 and 1 (each within the scatter of the next).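

Trifluoromethoxy in place of 3-fluorophenyl on this aromatic carbon gives a number 24 percentage points lower from compound 1 to compound 4 (beyond the scatter) in this assay, and this is the first pair shown that isolates a single change at this position. The step shows that the read-out depends on which group stands here, yet it does not vanish once the second ring is gone: without that ring, compound 4 still gives 26%. Nothing measured here explains the size of this step.

The compounds shown leave open whether the step follows from losing the six-membered aromatic ring or from the nature of the trifluoromethoxy group that replaces it. An unsubstituted phenyl, a methoxy group or an amine on the same carbon would help to separate these two readings.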